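From an aryl ether to a chloro substituent on the core

The source may hold more compounds than are shown below. What is called first, only, known or untested is meant among the compounds shown, and "the series" means these compounds.

Of the compounds shown here, three of one series have been measured in a functional assay on SGC-7901 cells (Homo sapiens) for inhibition, read by MTT assay, with a stated time of 48 h; a lower number here means a stronger inhibitor, a higher number a weaker inhibitor. Compound 1 `Cc1nnsc1CO/N=C/c1c(C)nn(C)c1Oc1cc(F)cc(F)c1` gives 9410 nM, compound 2 `CCc1nnsc1CO/N=C/c1c(C)nn(C)c1Oc1ccc(OC(F)(F)F)cc1` gives 13600 nM, and compound 3 `CCCc1nnsc1CO/N=C/c1c(C)nn(C)c1Oc1ccccc1C` gives 16300 nM. Compound 3 carries the highest of the three numbers, yet its distance to compound 2 and to compound 1 lies within the usual scatter, so the three stand level in this assay. Compound 4 `CCCc1nnsc1CO/N=C/c1c(C)nn(C)c1Cl` has not been measured; it differs from compound 3 by chloro in place of 2-methylphenoxy on an aromatic carbon. For the measured compounds named here, no measured pair shows a change of this kind, so no step size can be read from the data. The whole ring-bearing group leaves, and a modest weakening seems the likelier outcome. Compound 4 is therefore expected near 25000 nM, between 8000 nM and 80000 nM. That estimate would mean a 1.5-fold higher number from compound 3 to compound 4 (0.19 log units; within the scatter).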

Compound 4, half-maximal inhibitory concentration: > 50000 nM
Compound 4: only a limit was reported; the forecaster's own chance of this, stated with the estimate: 25%; at least 2.0-fold (0.30 log units) between middle value and limit.
By their numbers in this assay, from the lowest: compounds 1, 2 and 3 (each within the scatter of the next). At a limit, above all of these: compound 4.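

In this assay the exchange of 2-methylphenoxy for chloro on this aromatic carbon brings an at least 3.0-fold higher number from compound 3 to compound 4 (0.48 log units; beyond the scatter) and so gives the first difference in the series that lies beyond the scatter. For the compounds shown here, compounds 1, 2 and 3 all keep an aryloxy group at this position, so only this change shows that the position responds to losing it. Compound 4 gives a limit, not a number: the limit of > 50000 nM in this assay, at which 1 of the 4 values shown sits.

The compounds shown leave open whether the aromatic ring or the ether oxygen counts. A methoxy group or an amine at this position could separate the two.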